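Swapping Methyl for Bromo on the Sulfonyl Aryl Ring

A few compounds are considered here, and "the series" means these few. Any claim that something is new, unique, unknown or untested is made for them only; others in the source may bear on it.

Compound 1: `O=C(c1ccccc1)c1ccc(NS(=O)(=O)c2ccc(Cl)cc2Cl)cc1`, 82%
Compound 2: `Cc1ccc(S(=O)(=O)Nc2ccc(C(=O)c3ccccc3)cc2)cc1`, 35%

In an assay on CHO cells for binding affinity to integrin alpha-1 (Homo sapiens), read by WST assay, with a stated time of 2 h, tested at 50 uM (on this read-out higher numbers stand for more inhibition at the one concentration tested (going by the name of the read-out) and lower numbers for less inhibition), compound 2 gives the lower of the two numbers, with compound 1 the nearest at a higher value. Compound 3 `O=C(c1ccccc1)c1ccc(NS(=O)(=O)c2ccc(Br)cc2)cc1` differs from compound 2 by bromo in place of methyl on an aromatic carbon. Among the compounds with values here, the one measured step, a number 47 percentage points lower from compound 1 to compound 2 (beyond the scatter), shows that changing this ring can move the read-out widely, but no step tests bromo itself. A rise is expected for compound 3, estimated as a number 20 percentage points higher from compound 2 to compound 3 (beyond the scatter), landing at 55% with a range from 30% to 80%.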

Compound 3, a percentage reported as inhibition, at one concentration (the size of the read-out at that concentration, not a potency): 34%
Compound 3: the middle estimate sits 21 percentage points above what was measured, and the stated range covers the measured number.
By their numbers in this assay, from the lowest: compounds 3 and 2 (each within the scatter of the next); then compound 1.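

In this assay, the 4-bromophenyl ring reads like the 4-methylphenyl ring, with bromo in place of methyl giving (a number 1 percentage points lower from compound 2 to compound 3 (within the scatter)). The 2,4-dichlorophenyl ring of compound 1 also stands clear of this second ring, with 4-bromophenyl in its place giving (a number 48 percentage points lower from compound 1 to compound 3 (beyond the scatter)), so the large drop is not confined to the methyl compound. No measurement here accounts for these differences.

Still open, from the compounds shown here alone, is whether compound 1 owes its higher number to one chlorine or to both. Going by these compounds, how an amine or a carboxylic acid in place of bromo would read also remains open.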